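Phenyl in Place of Thiophen-2-yl: Compound 4 Awaited

The source may hold more compounds than are shown below. What is called first, only, known or untested is meant among the compounds shown, and "the series" means these compounds.

Compound 1 `Oc1cccc(-c2cc(-c3ccc(Cl)cc3)nc(-c3cccs3)c2)c1`: 11600 nM
Compound 2 `Oc1cccc(-c2cc(-c3cccc(Cl)c3)nc(-c3cccs3)c2)c1`: 2650 nM
Compound 3 `Oc1ccc(-c2cc(-c3ccncc3)nc(-c3ccc(Cl)cc3)c2)cc1`: "not determined" (no result reported)

In a functional assay on DU-145 cells (Homo sapiens) for cytotoxicity, read by CCK-8 assay and cell counting, with a stated time of 2 days (a lower number here means a stronger inhibitor, a higher number a weaker inhibitor), compound 1 stands highest of the two numbers that exist. Its nearest neighbour is compound 2, reached by a 4.4-fold lower number from compound 1 to compound 2 (0.64 log units; beyond the scatter), and compound 3 has no result to compare. Compound 4 `Oc1cccc(-c2cc(-c3ccccc3)nc(-c3ccc(Cl)cc3)c2)c1` differs from compound 1 by phenyl in place of thiophen-2-yl on an aromatic carbon. For the measured compounds named here, the one measured step concerns where the chlorine sits and says nothing about the five-membered ring, so nothing in hand bears directly on this exchange. With no guide in either direction, the expectation for compound 4 is a step of a 1.3-fold lower number from compound 1 to compound 4 (0.11 log units; within the scatter), that is, nothing beyond the scatter. Compound 4 is accordingly estimated at 9000 nM, within a range from 3000 nM to 30000 nM.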

Compound 4, half-maximal inhibitory concentration: 11200 nM
Estimate against measurement, compound 4: 1.2-fold (0.09 log units) below; low and high end bracket the measured number.
By their numbers in this assay, from the lowest: compound 2; then compounds 4 and 1 (each within the scatter of the next).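

In this assay, phenyl in place of thiophen-2-yl, next to the ring nitrogen, gives a 1.0-fold lower number from compound 1 to compound 4 (0.02 log units; within the scatter), so at this position the five-membered aromatic ring with its sulfur and the six-membered ring of carbon only cannot be told apart. Compound 1 and compound 2 both carry thiophen-2-yl here and could not show this. No measurement shown explains the result. On these data alone, whether an amine or a longer chain would be tolerated at this position stays open, as does whether phenyl would behave the same alongside the 3-chlorophenyl group of compound 2.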